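A few compounds are considered here, and "the series" means these few. Any claim that something is new, unique, unknown or untested is made for them only; others in the source may bear on it.

Working notes on the series. The shared core carries a basic side chain and a diaryl ether linking to an amide; compound 2 `COc1cc2c(Oc3ccc(NC(=O)c4cc(-c5ccccc5)ccn4)cc3F)ccnc2cc1OCCCN1CCCCC1` gives 790 nM in a functional assay on U-87MG ATCC cells (Homo sapiens) for cytotoxicity, read by MTT assay, with a stated time of 72 h; on this read-out higher numbers stand for weaker inhibition and lower numbers for stronger inhibition. Compound 1 `COc1ccc(-c2ccnc(C(=O)Nc3ccc(Oc4ccnc5cc(OCCCN6CCN(C)CC6)c(OC)cc45)c(F)c3)c2)c(OC)c1` has no number in this assay, its entry reading "not determined" (no result reported). Compound 3 `COc1cc2c(Oc3ccc(NC(=O)c4nccc(-c5ccccc5)n4)cc3F)ccnc2cc1OCCCN1CCCCC1` likewise stands without a number in this assay, the entry being "not determined" (no result reported), so the only figure to anchor the series is that of compound 2. Compound 4 `COc1cc2c(Oc3ccc(NC(=O)c4nccc(-c5ccc(F)cc5F)n4)cc3F)ccnc2cc1OCCCN1CCCCC1` differs from compound 3 by 2,4-difluorophenyl in place of phenyl on an aromatic carbon. Among the measured compounds shown here, with no measured step available for this change, no shift beyond the usual scatter is assumed in either direction, and the figure of compound 2 serves as the reference point. Compound 4 is therefore expected to give about 700 nM, with a range from 150 nM to 3500 nM.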

Compound 4, half-maximal inhibitory concentration: 780 nM
Compound 4: the middle estimate sits 1.1-fold (0.05 log units) below what was measured, within the range that was stated.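

No new step can be read from compound 3 and compound 4 in this assay; compound 3 carries no single number there. The compounds shown leave open what 2,4-difluorophenyl in place of phenyl does to this read-out. No evidence at hand bears on the result.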